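Compound 3: a larger group on the amine nitrogen

A few compounds are considered here, and "the series" means these few. Any claim that something is new, unique, unknown or untested is made for them only; others in the source may bear on it.

Within the data shown here, in a functional assay on HeLa cells (Homo sapiens) for inhibition, read by MTT assay, with a stated time of 48 h (on this read-out higher numbers stand for weaker inhibition and lower numbers for stronger inhibition), compound 2 (`CCOC(=O)C1=C(N/N=C(/Cl)C#N)Nc2[nH]nc(C)c2C1c1ccc(N(C)C)cc1`) stands at 26200 nM as the lower of the two numbers so far, while compound 1 (`CCOC(=O)C1=C(N/N=C(/Br)c2ccccc2)Nc2[nH]nc(C)c2C1c1ccc(N(C)C)cc1`) stands at 75700 nM on the same scale. Compound 3 (`CCOC(=O)C1=C(N/N=C(/C(C)=O)C(=O)OCC)Nc2[nH]nc(C)c2C1c1ccc(N(C)C)cc1`) keeps the shared core, and the change from compound 2 is a group of 10 heavy atoms (6 carbon, 1 nitrogen, 3 oxygen; no ring) in place of a group of 5 heavy atoms (2 carbon, 2 nitrogen, 1 chlorine; no ring), on an amine nitrogen with nothing else altered. Among the measured compounds shown here, only one measured step bears on this: a 2.9-fold lower number from compound 1 to compound 2 (0.46 log units; beyond the scatter) came with a smaller group replacing a larger one and was modest in size. For the measured compounds named here, no measured compound carries the entering group, so this single step is thin support. Growing the group is therefore expected to move this assay towards a higher number, by a step no larger than that one and possibly within the scatter. The expected step is a 1.7-fold higher number from compound 2 to compound 3 (0.23 log units; within the scatter) as a working figure. The estimated value of compound 3 is 45000 nM (16000 nM to 110000 nM).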

Compound 3, half-maximal inhibitory concentration: > 100000 nM
Compound 3: only a limit was reported (the forecaster's own chance of this, stated with the estimate: 10%); middle value at least 2.2-fold (0.34 log units) away from the limit.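

In this assay, compound 3 is reported only as a limit, not as a number: the limit of > 100000 nM in this assay, at which 1 of the 3 values shown sits.

Even as a floor, an at least 3.8-fold higher number from compound 2 to compound 3 (0.58 log units; beyond the scatter) shows that two groups without a ring can differ beyond the scatter on this amine nitrogen, which compound 1 and compound 2 alone could not show. The other step, an at least 1.3-fold higher number from compound 1 to compound 3 (0.12 log units; that floor lies within the scatter), has a floor within the scatter, so on its own it does not show that the entering group does worse than the ring-bearing group.

On these data alone, whether the higher number goes with the count of heavy atoms or with the carbonyl groups of the entering group stays open, as size and atoms change together in this step. A plain alkyl chain of similar size on this amine nitrogen would separate the two.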